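The source may report more compounds than this note shows. Statements on the series, on what has been measured and on what is new or still open speak of the compounds shown alone.

Measured compounds:
compound 1, `COC(=O)c1c(NC(=O)N2CCN(C)CC2)sc2c1CCC2`, 450 nM
compound 2, `CCCOC(=O)c1c(NC(=O)N2CCN(C)CC2)sc2c1CCC2`, 14200 nM
compound 3, `CC(C)OC(=O)c1c(NC(=O)N2CCN(C)CC2)sc2c1CCC2`, 4590 nM

In an assay on cells for agonist activity at Toll-like receptor 2 (Homo sapiens), with a stated time of 24 h (on this read-out higher numbers stand for an effect only at larger amounts of compound and lower numbers for an effect already at smaller amounts), compound 3 stands second highest of the three numbers: it gives 4590 nM, with compound 2 nearest, a 3.1-fold lower number from compound 2 to compound 3 (0.49 log units; beyond the scatter), and compound 1 furthest, a 10-fold higher number from compound 1 to compound 3 (1.01 log units; beyond the scatter). Compound 4, `CN1CCN(C(=O)Nc2sc3c(c2C(=O)O)CCC3)CC1`, has not yet been measured in this assay. It differs from compound 3 by hydrogen in place of isopropyl on an oxygen next to a carbonyl group, so that the isopropoxycarbonyl group becomes carboxy.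

All three measured steps change only the alkyl group on that oxygen. The methyl compound gives the lowest number, the propyl compound the highest, and isopropyl lies between them, as a 32-fold higher number from compound 1 to compound 2 (1.50 log units; beyond the scatter) and a 3.1-fold lower number from compound 2 to compound 3 (0.49 log units; beyond the scatter) show. None of these steps removes the alkyl group altogether, so the change to compound 4 goes beyond what the measured compounds cover. Taking the smallest group as the nearest guide, compound 4 is expected to give a lower number than compound 3, a 3.1-fold lower number from compound 3 to compound 4 (0.49 log units; beyond the scatter), though with wide uncertainty. The estimate for compound 4 in this assay is 1500 nM, within 200 nM to 15000 nM.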

Compound 4, half-maximal effective concentration: "not active" (no number reported)
Compound 4: no number reported; the estimate stays without a comparison.
By their numbers in this assay, from the lowest: compound 1; then compound 3; then compound 2.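

In this assay, within the data shown here, compound 4 is reported as not active, with no number, so no step from compound 1, compound 2 or compound 3 to compound 4 can be read. The compounds shown leave open how far carboxy in place of isopropoxycarbonyl shifts this read-out, and no other data here bear on the result.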